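A Smaller Group on the Ring Nitrogen

The source may report more compounds than this note shows. Statements on the series, on what has been measured and on what is new or still open speak of the compounds shown alone.

Of the compounds shown here, three built on one shared core have been tested in a functional assay (Oryctolagus cuniculus) for antagonist activity at platelet-activating factor receptor (Cavia porcellus); on this read-out lower numbers stand for stronger inhibition and higher numbers for weaker inhibition. Compound 1 `O=C(c1ccn2c1CSC2c1cccnc1)c1c[nH]c2cccc(O)c12` gives 327 nM. Compound 2 `CN(C)C(=O)n1cc(C(=O)c2ccn3c2CSC3c2cccnc2)c2ccc(Sc3ccc(F)cc3)cc21` gives 17 nM. Compound 3 `CCNC(=O)n1cc(C(=O)c2ccn3c2CSC3c2cccnc2)c2ccc(-c3ccc(F)cc3)cc21` gives 19 nM. Compound 3 therefore stands second highest of the three numbers; its nearest neighbour is compound 2, whose value lies within the scatter of repeated measurements, so no order between compound 2 and compound 3 can be read from them, while compound 1 lies well beyond the scatter with a clearly higher number.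

The next compound keeps the fluorophenyl group of compound 3 and changes only the group on the ring nitrogen. Compound 4 `Cn1cc(C(=O)c2ccn3c2CSC3c2cccnc2)c2ccc(-c3ccc(F)cc3)cc21` carries methyl in place of ethylcarbamoyl on an aromatic nitrogen, that is, methyl in place of ethylcarbamoyl on an aromatic nitrogen. Within the data shown here, no pair among the measured compounds differs in this place alone, so no measured step shows what such a change does; the only guidance is that compound 1, which has neither a carbamoyl group nor the fluorophenyl group, gives the highest number of the three.

On this basis a small loss in this assay is expected, a 2.1-fold higher number from compound 3 to compound 4 (0.32 log units; beyond the scatter), though a value within the scatter of compound 3 would not surprise. Compound 4 is estimated at 40 nM, with a likely range from 12 nM to 150 nM.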

Compound 4, inhibition constant: 7 nM
Compound 4: the middle estimate sits 5.7-fold (0.76 log units) above what was measured; measured number outside the range, below it.
By their numbers in this assay, from the lowest: compound 4; then compounds 2 and 3 (each within the scatter of the next); then compound 1.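

Among these compounds, this is the first step measured at the ring nitrogen: in this assay, methyl in place of ethylcarbamoyl gives a 2.7-fold lower number from compound 3 to compound 4 (0.43 log units; beyond the scatter). So the ethylcarbamoyl group, with its carbonyl and its amide hydrogen, is not needed on this aromatic nitrogen for strong inhibition, since a single methyl carbon with no hydrogen-bond donor or acceptor gives a lower number when the rest of compound 3 is kept. Nothing available here accounts for the lower number with the smaller group.

With only methyl and ethylcarbamoyl compared at this nitrogen, the step gives a single contrast rather than a trend with size, and it cannot say where a plain hydrogen, an ethyl group or a longer chain such as propyl would fall. It also leaves open whether methyl would give a similar step on the compound 2 framework, which has a dimethylcarbamoyl group on this nitrogen and a sulfur atom linking its fluorophenyl group to the core.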